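The compounds below may be only part of what the source reports. "The series", "measured", "known", "first", "only" and "open" are said of these compounds alone.

Compound 3 `CC(C)(C)N(NC(=O)c1cccc(Cl)c1)C(=O)c1ccccc1Cl` carries a chlorine on each of its two aromatic rings. In an assay on cells for agonist activity at ecdysone receptor (Bombyx mori), read by a luciferase reporter, with a stated time of 24 h (on this read-out higher numbers stand for an effect only at larger amounts of compound and lower numbers for an effect already at smaller amounts), compound 3 gives 155 nM, the highest number among the three measured compounds. Compound 1 `CC(C)(C)N(NC(=O)c1ccccc1)C(=O)c1ccccc1I` gives 105 nM, close to compound 3 and within the scatter of it, while compound 2 `Cc1cc(C)cc(C(=O)N(NC(=O)c2ccccc2)C(C)(C)C)c1` gives 69.2 nM, beyond the scatter from compound 3. For the measured compounds named here, the only one-place step so far, a 1.5-fold lower number from compound 1 to compound 2 (0.18 log units; within the scatter), changes the aromatic ring on the other carbonyl carbon, the one attached to the nitrogen that carries the tert-butyl group.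

Compound 4 `CC(C)(C)N(NC(=O)c1ccc(C#N)cc1)C(=O)c1ccccc1Cl` differs from compound 3 in one place: 4-cyanophenyl in place of 3-chlorophenyl on a carbonyl carbon. Going by the values given here, no measured step exchanges a ring at this carbonyl, and the one step that exchanges an aromatic ring anywhere stays within the scatter, so for compound 4 no step beyond the scatter is expected, a 1.0-fold lower number from compound 3 to compound 4 (0.01 log units; within the scatter). Compound 4 is therefore estimated at 150 nM, within a range from 50 nM to 450 nM.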

Compound 4, half-maximal effective concentration: 603 nM
Estimate against measurement, compound 4: 4.0-fold (0.60 log units) below; measured number above the stated range.
By their numbers in this assay, from the lowest: compounds 2, 1 and 3 (each within the scatter of the next, the first and the last beyond it); then compound 4.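

In this assay, putting 4-cyanophenyl in place of 3-chlorophenyl on this carbonyl carbon gives a 3.9-fold higher number from compound 3 to compound 4 (0.59 log units; beyond the scatter). For the compounds shown here, the only earlier step, a 1.5-fold lower number from compound 1 to compound 2 (0.18 log units; within the scatter), exchanged a ring on the other carbonyl, so this is the first sign that a one-place ring change can move the number clearly, here towards needing more compound. Nothing measured here explains the shift.

Still open, on these data alone, is how 4-chlorophenyl or 3-cyanophenyl would read on this carbonyl carbon, which would help separate the effect of the group from that of its place on the ring. As far as these compounds go, an amine such as 4-aminophenyl is equally open.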